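This account rests on a few compounds, and the source may have more. Where it says the series, first, only, none or still open, it means among the compounds named here.

Compound 1, `CCCCc1ccc(COC(=O)N[C@H]2CNC2=O)cc1`, gives 23 nM in an assay on HEK293 cells for inhibition of N-acylethanolamine-hydrolyzing acid amidase (Homo sapiens), read by fluorescence, with stated times of 10 min and 50 min; on this read-out higher numbers stand for weaker inhibition and lower numbers for stronger inhibition.
Compound 2, `CC(OC(=O)N[C@H]1CNC1=O)c1ccc(C2CCCCC2)cc1`, gives 4470 nM in this assay.

Compound 1 holds the lower of the two numbers; compound 2 sits far above it, a gap beyond the usual scatter, though the two differ in more than one place. Compound 3, `O=C(N[C@H]1CNC1=O)OCc1ccc(-c2cccnc2)cc1`, carries pyridin-3-yl in place of butyl on an aromatic carbon. Within the data shown here, no measured pair tells what such a swap does here, so the expectation rests on compound 1 alone. A modest weakening is expected in this assay, with the step of a 2.6-fold higher number from compound 1 to compound 3 (0.42 log units; beyond the scatter) expected to stay small. Compound 3 is expected to give about 60 nM, within 10 nM to 400 nM.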

Compound 3, half-maximal inhibitory concentration: 8110 nM
For compound 3 the middle estimate is 140-fold (2.13 log units) below the measured one; measured number outside the range, above it.
By their numbers in this assay, from the lowest: compound 1; then compounds 2 and 3 (each within the scatter of the next).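

The group on this aromatic carbon, para to a large group, strongly affects inhibition in this assay: pyridin-3-yl in place of butyl gives a 350-fold higher number from compound 1 to compound 3 (2.55 log units; beyond the scatter). Among these compounds, this is the first change in a single place, and it shows that replacing an open chain with a six-membered aromatic ring containing nitrogen can sharply weaken inhibition on this core. No measured evidence here explains the loss.

Going by these compounds, it remains open whether the loss follows the ring or its nitrogen: a phenyl group on this carbon would separate the two. A pentyl chain would show how much chain length itself counts.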